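This account rests on a few compounds, and the source may have more. Where it says the series, first, only, none or still open, it means among the compounds named here.

In an ADME assay on J774.A1 cells (Mus musculus) for cytotoxicity, read by MTT assay, with a stated time of 48 h (a lower number here means that less compound is tolerated, a higher number that more compound is tolerated), compound 2 `COc1ccc(CNC(=O)c2c([N+](=O)[O-])noc2-c2ccc(Cl)cc2)cc1` gives 89500 nM and compound 3 `COc1cccc(CNC(=O)c2c([N+](=O)[O-])noc2-c2ccc(Cl)cc2)c1` gives 68600 nM. Among the compounds with values here, these two numbers agree within the scatter, so compound 3 stands level with its only measured neighbour. Compound 1 `COc1ccc(CNC(=O)c2c([N+](=O)[O-])noc2-c2ccc([N+](=O)[O-])cc2)cc1OC` offers no number, its entry being "not determined" (no result reported). Compound 4 `COc1ccc(CNC(=O)c2c([N+](=O)[O-])noc2-c2ccc(Cl)cc2)cc1OC` has methoxy in place of hydrogen on an aromatic carbon, ortho to a methoxy group and para to a large group (methoxy in place of hydrogen on an aromatic carbon). Within the data shown here, the only measured step that bears on this, a 1.3-fold lower number from compound 2 to compound 3 (0.12 log units; within the scatter), moves a methoxy group rather than adding one, so it is indirect evidence. It lies within the scatter, so no step beyond the scatter is expected in this assay. The expected step is a 1.1-fold higher number from compound 3 to compound 4 (0.04 log units; within the scatter). For compound 4 the estimate is 75000 nM, with an expected range of 35000 nM to 140000 nM.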

Compound 4, half-maximal cytotoxic concentration: 106000 nM
Compound 4: middle estimate off by 1.4-fold (0.15 log units), on the low side; the measured number falls inside the stated range.
By their numbers in this assay, from the lowest: compounds 3, 2 and 4 (each within the scatter of the next).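

Methoxy in place of hydrogen on an aromatic carbon can now be read directly in this assay, and from two starting points: (a 1.5-fold higher number from compound 3 to compound 4 (0.19 log units; within the scatter)) and (a 1.2-fold higher number from compound 2 to compound 4 (0.07 log units; within the scatter)). Both steps lie within the scatter, so this added methoxy group does not set compound 4 apart from compound 2 or compound 3 in the amount of compound tolerated. No measurement shown gives a reason for this result.

Still open, from the compounds shown here alone, is whether a different group on this aromatic carbon, such as an amine or a carboxylic acid, would give a step beyond the scatter.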